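This account rests on a few compounds, and the source may have more. Where it says the series, first, only, none or still open, it means among the compounds named here.

Measured so far:
Compound 1, `CN1CCN(CC(=O)Nc2ccc(-c3nc4cc(C(F)(F)F)ccc4n3C)cc2)CC1`: 44000 nM
Compound 2, `O=[N+]([O-])c1ccc(-c2nc3cc(C(F)(F)F)ccc3[nH]2)c([N+](=O)[O-])c1`: 16000 nM

In an ADME assay on MDBK cells (Bos taurus) for cytotoxicity, read by MTT assay, with a stated time of 96 h (on this read-out lower numbers stand for higher toxicity in this test and higher numbers for lower toxicity in this test), compound 1 gives 44000 nM, the highest of the two numbers measured, so of this pair it is the one that harms the cells least. Compound 2 gives 16000 nM in this assay, and the gap between the two values lies beyond the usual scatter, so compound 2 is the more toxic of the two. Compound 3 `Cn1c(-c2ccc(NC(=O)CN3CCCCC3)cc2)nc2cc(C(F)(F)F)ccc21` has not yet been tested in this assay. It differs from compound 1 in one place: piperidin-1-yl in place of 4-methylpiperazin-1-yl on a saturated chain carbon bound to a carbonyl carbon. Within the data shown here, no measured pair shows a change of this kind, so there is no earlier step to rest on; the only anchor is the value of compound 1 itself. Because compound 1 gives 44000 nM and the change is confined to one small ring, I expect a step from compound 1 to compound 3 of a 1.4-fold lower number from compound 1 to compound 3 (0.14 log units; within the scatter), a small move toward a lower number that may well stay within the scatter. For compound 3 in this assay I estimate 32000 nM, with a likely range from 13000 nM to 80000 nM.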

Compound 3, half-maximal cytotoxic concentration: 100000 nM
The estimate for compound 3 lay 3.1-fold (0.49 log units) below the measured number, and the stated range ends below it.
By their numbers in this assay, from the lowest: compound 2; then compound 1; then compound 3.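

In this assay, putting piperidin-1-yl in place of 4-methylpiperazin-1-yl on a saturated chain carbon bound to a carbonyl carbon gives a 2.3-fold higher number from compound 1 to compound 3 (0.36 log units; beyond the scatter), so a change confined to this one ring is enough to shift the read-out toward lower toxicity in this test. The ring that enters holds one hetero atom where the ring that leaves holds 2, and it has no methyl group, while the rest of the molecule stays the same, which ties the modest rise to this single place. Nothing measured here explains why the number rises with this swap.

The compounds shown leave open whether the rise goes with the loss of the second ring nitrogen or with the loss of its methyl group, a question that a piperazine ring without the methyl or a morpholine ring, with oxygen in place of that nitrogen, could help to separate. Also open, as far as these compounds go, is whether the same swap would move the number in the same direction with a longer chain between the carbonyl and the ring.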